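Side-chain amine swap on the shared core: solubility outlook

A few compounds are considered here, and "the series" means these few. Any claim that something is new, unique, unknown or untested is made for them only; others in the source may bear on it.

Three compounds with the shared core of compound 1 `Cc1ccc2c(c1)[n+]([O-])c(NCCN(C)C)n[n+]2[O-]` have been measured in a physicochemical assay for solubility, in the presence of a further agent that is not named here; a higher number here means a more soluble compound, a lower number a less soluble compound. Compound 1 gives > 51000000 nM, which is a limit of the assay rather than a number. Compound 2 `CC(C)c1ccc2c(c1)[n+]([O-])c(NCCN(C)C)n[n+]2[O-]` gives 42000000 nM in this assay. Compound 3 `COc1ccc2c(c1)[n+]([O-])c(NCCN(C)C)n[n+]2[O-]` gives 46000000 nM in this assay, the highest of the two numbers, with compound 2 nearest: a 1.1-fold higher number from compound 2 to compound 3 (0.04 log units; within the scatter). The other steps, an at least 1.2-fold lower number from compound 1 to compound 2 (0.08 log units; that floor lies within the scatter) and an at least 1.1-fold lower number from compound 1 to compound 3 (0.04 log units; that floor lies within the scatter), also stay within the scatter, and all three steps change only the group on the aromatic carbon.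

Compound 4 `COc1ccc2c(c1)[n+]([O-])c(NCCN1C(C)CCCC1C)n[n+]2[O-]` differs from compound 3 on the side chain: 2,6-dimethylpiperidin-1-yl in place of dimethylamino on a saturated chain carbon, two bonds along the chain from a nitrogen on an aromatic ring. Within the data shown here, no measured step touches that position, so none bears on the change directly, and the aromatic changes fix no direction for it. A lower number is nonetheless expected for compound 4, estimated as 20000000 nM (range 6000000 nM to 46000000 nM) in this assay. The expected step is a 2.3-fold lower number from compound 3 to compound 4 (0.36 log units; beyond the scatter), taking the measured value of compound 3, 46000000 nM, as the starting point.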

Compound 4, solubility: 29000000 nM
For compound 4 the middle estimate is 1.5-fold (0.16 log units) below the measured one, within the range that was stated.
By their numbers in this assay, from the lowest: compounds 4, 2 and 3 (each within the scatter of the next). At a limit, above all of these: compound 1.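

In this assay, among these compounds, the first step at this side-chain position, 2,6-dimethylpiperidin-1-yl in place of dimethylamino on a saturated chain carbon, two bonds along the chain from a nitrogen on an aromatic ring, gives a 1.6-fold lower number from compound 3 to compound 4 (0.20 log units; within the scatter). The swap from an open group of 3 heavy atoms to a six-membered non-aromatic ring of 8 heavy atoms therefore yields a step that cannot be told apart from repeat scatter, as with the changes on the aromatic carbon. Compound 1 remains a limit of the assay and not a number: the limit of > 51000000 nM in this assay, at which 1 of the 4 values shown sits.

Going by these compounds, whether piperidin-1-yl without the two methyl groups, morpholin-4-yl or a longer chain would give a step beyond the scatter stays open. Also open, on these data alone, is whether the same swap reads alike with methyl or isopropyl on the aromatic carbon.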